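Swapping trifluoromethyl for chloro on the urea aryl ring

The source may hold more compounds than are shown below. What is called first, only, known or untested is meant among the compounds shown, and "the series" means these compounds.

The series shares one core, seen in compound 1 `COc1cc(Cl)cc(-c2nn(-c3cccc(NC(=O)c4ccc(Cl)c(Cl)c4)c3)cc2-c2ccncc2)c1`, compound 2 `O=C(Nc1cccc(-n2cc(-c3ccncc3)c(-c3cc(O)cc(Cl)c3)n2)c1)Nc1ccc(Cl)c(Cl)c1` and compound 3 `COc1cc(Cl)cc(-c2nn(-c3cccc(NC(=O)Nc4ccc(Cl)c(C(F)(F)F)c4)c3)cc2-c2ccncc2)c1`. In a functional assay on OVCAR-4 cells (Homo sapiens) for inhibition, read by sulforhodamine B assay, with a stated time of 48 h, tested at 10 uM (on this read-out higher numbers stand for a weaker effect at the one concentration tested and lower numbers for a stronger effect), compound 1 gives 58.6%, compound 2 gives 10.7% and compound 3 gives 16.6%. Compound 3 thus stands second highest of the three numbers; its value and that of compound 2 lie within the scatter of each other, while compound 1 sits well apart. Going by the values given here, the one measured step that bears here is a number 42 percentage points lower from compound 1 to compound 3 (beyond the scatter), which combined the amide-to-urea change with the trifluoromethyl group. Compound 4 `COc1cc(Cl)cc(-c2nn(-c3cccc(NC(=O)Nc4ccc(Cl)c(Cl)c4)c3)cc2-c2ccncc2)c1` is unmeasured; it differs from compound 3 by chloro in place of trifluoromethyl on an aromatic carbon. Since compound 2, a urea carrying 3,4-dichlorophenyl, gives 10.7%, the account expects compound 4 to stay close to compound 3, an estimated step of a number 2.6 percentage points lower from compound 3 to compound 4 (within the scatter) in this assay, within the scatter. The estimated value for compound 4 is 14%, with a range from 5% to 30%.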

Compound 4, a percentage reported as activity, at one concentration (the size of the read-out at that concentration, not a potency): 13.3%
For compound 4 the middle estimate is 0.7 percentage points above the measured one; measured number inside the range.
By their numbers in this assay, from the lowest: compounds 2, 4 and 3 (each within the scatter of the next); then compound 1.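

In this assay, chloro in place of trifluoromethyl on this aromatic carbon, ortho to a chloro group, gives a number 3.3 percentage points lower from compound 3 to compound 4 (within the scatter) and so shows that the two groups read alike at this position. With the aryl ring now the same on both sides, a number 45.3 percentage points lower from compound 1 to compound 4 (beyond the scatter) ties the large gap to the change from 3,4-dichlorophenyl to (3,4-dichlorophenyl)amino on the carbonyl carbon alone, a change that the step to compound 3 had mixed with the trifluoromethyl group. Methyl in place of hydrogen on the oxygen gives a number 2.6 percentage points higher from compound 2 to compound 4 (within the scatter) and likewise leaves the two compounds within the scatter of each other. The compounds shown leave open how a nitrile or a methyl group would read at the position of the trifluoromethyl group. No supporting measurement bears on why these steps take the sizes they do.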